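Swapping the fluorinated side chain of compound 2

A few compounds are considered here, and "the series" means these few. Any claim that something is new, unique, unknown or untested is made for them only; others in the source may bear on it.

Measured in an ADME assay for permeability, using PAMPA, with a stated time of 4 h, at pH 7.4; a lower number here means that the compound crosses the layer more slowly, a higher number that the compound crosses the layer faster:
- compound 1 `C/C(CN)=C(/F)CN(C[C@H]1Cc2ccccc2CN1)[C@H]1CCCc2cccnc21`: 220 nm/s
- compound 2 `C/C(CN(C[C@H]1Cc2ccccc2CN1)[C@H]1CCCc2cccnc21)=C(/F)CN`: 700 nm/s

Of these two, compound 2 stands highest at 700 nm/s. Compound 3 `C/C(CN)=C(\F)CN(C[C@H]1Cc2ccccc2CN1)[C@H]1CCCc2cccnc21` differs from it on a saturated chain carbon bound to an amine nitrogen: 2-(aminomethyl)-1-fluoroprop-1-en-1-yl in place of 3-amino-2-fluoro-1-methylprop-1-en-1-yl on a saturated chain carbon bound to an amine nitrogen. Among the measured compounds shown here, only one measured step involves these two named groups, and it runs the opposite way: a 3.2-fold higher number from compound 1 to compound 2 (0.50 log units; beyond the scatter). Reversing that single step suggests a lower number, though one step is thin support. The expected change is a 2.5-fold lower number from compound 2 to compound 3 (0.40 log units; beyond the scatter). For compound 3 the estimated value is 280 nm/s (expected range 120 nm/s to 650 nm/s).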

Compound 3, apparent permeability: 490 nm/s
Beside the measured number, compound 3's estimate is 1.8-fold (0.24 log units) below it; low and high end bracket the measured number.
By their numbers in this assay, from the lowest: compound 1; then compounds 3 and 2 (each within the scatter of the next).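

In this assay, exchanging the two side chains at this place on a saturated chain carbon bound to an amine nitrogen gives no clear difference once the double bond is drawn as in compound 3: a 1.4-fold lower number from compound 2 to compound 3 (0.15 log units; within the scatter). The earlier gap between these two groups therefore holds only for compound 1. With 2-(aminomethyl)-1-fluoroprop-1-en-1-yl kept in place, a 2.2-fold higher number from compound 1 to compound 3 (0.35 log units; beyond the scatter), and this step can be tied to the double bond alone: the fact that compounds 1 and 3 differ only in the configuration as drawn.

Going by these compounds, whether the same holds with a hydroxyl in place of the amine, or chlorine in place of fluorine, stays open. Also open, on these data alone, is how 3-amino-2-fluoro-1-methylprop-1-en-1-yl behaves with its double bond drawn the other way.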